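Working notes: from compound 3 to compound 4

A few compounds are considered here, and "the series" means these few. Any claim that something is new, unique, unknown or untested is made for them only; others in the source may bear on it.

Measured in an ADME assay on LLC-PK1 cells (Sus scrofa) for permeability; a lower number here means that the compound crosses the layer more slowly, a higher number that the compound crosses the layer faster:
Compound 1 `C[C@]1(c2cc(NC(=O)c3ccc(Cl)cn3)cc(F)c2F)N=C(N)S[C@@]2(C#N)C[C@H]21`: 39 10^-6 cm/s
Compound 2 `CCOc1cnc(C(=O)Nc2cc(F)c(F)c([C@@]3(C)N=C(N)S[C@@]4(COC)C[C@H]43)c2)cn1`: 25 10^-6 cm/s
Compound 3 `COC[C@]12C[C@H]1[C@@](C)(c1cc(NC(=O)c3cnc(OCC(F)(F)F)cn3)cc(F)c1F)N=C(N)S2`: 25 10^-6 cm/s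

Compound 3 stands level with compound 2, and compound 1 lies within the scatter of compound 3, so the three numbers do not separate. Compound 4 `COC[C@]12C[C@H]1[C@@](C)(c1cc(NC(=O)c3cnc(OCCC(F)(F)F)cn3)cc(F)c1F)N=C(N)S2` has 2,2,2-trifluoroethyl in place of trifluoromethyl on a saturated chain carbon bound to an oxygen on an aromatic ring. Read one bond further out, this is 2,2,2-trifluoroethoxy to 3,3,3-trifluoropropoxy.

Within the data shown here, only one measured step bears on this place, and it swaps trifluoromethyl for methyl: no change at the digits printed from compound 2 to compound 3 (within the scatter). Among the measured compounds shown here, this single step is thin evidence, and no measured compound yet carries the longer chain. Even so, no shift beyond the scatter is expected in this assay. The estimated step is a 1.0-fold higher number from compound 3 to compound 4 (0.02 log units; within the scatter). For compound 4 the expected value is 26 10^-6 cm/s, with an estimated range of 16 10^-6 cm/s to 40 10^-6 cm/s.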

Compound 4, apparent permeability: 23 10^-6 cm/s
Compound 4: middle estimate off by 1.1-fold (0.05 log units), on the high side; the measured number falls inside the stated range.
By their numbers in this assay, from the lowest: compounds 4, 2, 3 and 1 (each within the scatter of the next).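

In this assay the change from 2,2,2-trifluoroethoxy to 3,3,3-trifluoropropoxy gives a 1.1-fold lower number from compound 3 to compound 4 (0.04 log units; within the scatter) and so extends the chain at this place without a step beyond the scatter. Placing trifluoromethyl on the end of the ethoxy chain gives a 1.1-fold lower number from compound 2 to compound 4 (0.04 log units; within the scatter) and shows that the longer fluorinated chain also stays within the scatter of the unfluorinated ethoxy group, so the three ethers at this position do not separate in this read-out. No supporting data on hand offer a reason for this flat result.

From the compounds shown here alone, whether an amine, a carboxylic acid or a longer chain at this place would produce a step beyond the scatter remains open. Compound 1 differs from these three in more than one place, so it says nothing about this position alone.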